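Swapping an ester chain for cyclobutyl at the charged nitrogen

The source may report more compounds than this note shows. Statements on the series, on what has been measured and on what is new or still open speak of the compounds shown alone.

Compound 1 `CC(C)(C)OC(=O)CCC[N+]1(C)CCc2c(sc(NC(=O)Nc3ccc(Cl)cc3)c2C(N)=O)C1`: 250 nM
Compound 2 `C[N+]1(CC2CCCCC2)CCc2c(sc(NC(=O)Nc3ccc(Cl)cc3)c2C(N)=O)C1`: 100 nM
Compound 3 `CC(C)(C)OC(=O)CCCCC[N+]1(C)CCc2c(sc(NC(=O)Nc3ccc(Cl)cc3)c2C(N)=O)C1`: 110 nM

In a functional assay (strain AB) with Danio rerio as the target, read by microscopy, with a stated time of 1 h (a higher number here means that more compound is needed for the effect, a lower number that less compound is needed), compound 3 gives 110 nM. The data show a 1.1-fold higher number from compound 2 to compound 3 (0.04 log units; within the scatter) and a 2.3-fold lower number from compound 1 to compound 3 (0.36 log units; beyond the scatter), so compound 3 stands level with compound 2, and both lie under compound 1.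

Compound 4 `C[N+]1(CC2CCC2)CCc2c(sc(NC(=O)Nc3ccc(Cl)cc3)c2C(N)=O)C1` has not yet been measured. It carries cyclobutyl in place of 4-(tert-butoxycarbonyl)butyl on a saturated chain carbon bound to an amine nitrogen in a ring.

Within the data shown here, no cyclobutyl compound has a measured value. The nearest guide is compound 2, which has cyclohexyl at that place and shows a 1.1-fold higher number from compound 2 to compound 3 (0.04 log units; within the scatter). The wider a 2.5-fold lower number from compound 1 to compound 2 (0.40 log units; beyond the scatter) involves the other ester chain and bears less directly.

The step expected in this assay is a 1.2-fold higher number from compound 3 to compound 4 (0.07 log units; within the scatter), and none beyond the scatter is expected. Compound 4 is expected at 130 nM, with an estimated range of 50 nM to 320 nM.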

Compound 4, half-maximal effective concentration: 210 nM
For compound 4 the middle estimate is 1.6-fold (0.21 log units) below the measured one; measured number inside the range.
By their numbers in this assay, from the lowest: compounds 2, 3, 4 and 1 (each within the scatter of the next, the first and the last beyond it).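

In this assay, among these compounds, cyclobutyl and cyclohexyl are not interchangeable at this place: the change gives a 2.1-fold higher number from compound 2 to compound 4 (0.32 log units; beyond the scatter) and is the one new step beyond the scatter, though a modest one. Cyclobutyl cannot be told apart from either ester chain, with a 1.9-fold higher number from compound 3 to compound 4 (0.28 log units; within the scatter) and a 1.2-fold lower number from compound 1 to compound 4 (0.08 log units; within the scatter) as the two remaining steps, even though those two chains differ from each other beyond the scatter. No measured evidence accounts for any of these steps.

Still open, on these data alone, is whether cyclopentyl at this place would stand with cyclohexyl or with cyclobutyl, and what a carboxylic acid in place of the tert-butyl ester would do on either chain.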